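The source may report more compounds than this note shows. Statements on the series, on what has been measured and on what is new or still open speak of the compounds shown alone.

Working notes on the series. In a functional assay on HepG2 cells (Homo sapiens) for cytotoxicity, read by MTT assay, with a stated time of 72 h (on this read-out lower numbers stand for stronger inhibition and higher numbers for weaker inhibition), compound 1 `Cc1cc(=O)n(-c2ccccc2C(F)(F)F)nc1C(=O)Nc1ccc(Oc2ncnc3ccsc23)cc1` gives 9230 nM. In this assay compound 2 `Cc1cc(=O)n(-c2ccc(Br)cc2F)nc1C(=O)Nc1ccc(Oc2ncnc3ccsc23)cc1` gives 10600 nM, and the two numbers sit within the scatter of each other: the step of a 1.1-fold higher number from compound 1 to compound 2 (0.06 log units; within the scatter). Compound 3 `Cc1cc(=O)n(-c2ccccc2OC(F)(F)F)nc1C(=O)Nc1ccc(Oc2ncnc3ccsc23)cc1` differs from compound 2 only in the group on the aromatic nitrogen, (2-(trifluoromethoxy)phenyl in place of 4-bromo-2-fluorophenyl on an aromatic nitrogen). For the measured compounds named here, the one measured step bearing on this position, from compound 1 to compound 2, was within the scatter, so no step beyond the scatter is expected in this assay. Compound 3 is therefore estimated at 9500 nM, range 3000 nM to 30000 nM, a step of a 1.1-fold lower number from compound 2 to compound 3 (0.05 log units; within the scatter).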

Compound 3, half-maximal inhibitory concentration: 25000 nM
Estimate against measurement, compound 3: 2.6-fold (0.42 log units) below; measured number inside the range.
By their numbers in this assay, from the lowest: compounds 1 and 2 (each within the scatter of the next); then compound 3.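

The position on the aromatic nitrogen is not indifferent in this assay: the earlier pair stayed within the scatter, but a 2.4-fold higher number from compound 2 to compound 3 (0.37 log units; beyond the scatter) lies beyond it, if modestly. A change confined to the ortho group also registers, trifluoromethoxy in place of trifluoromethyl giving a 2.7-fold higher number from compound 1 to compound 3 (0.43 log units; beyond the scatter), so one added oxygen in that group is enough to separate compound 3 from compound 1.

As far as these compounds go, whether a phenyl group carrying an amine or a carboxylic acid would lower the number at this position remains open. Nothing available here accounts for the higher number of compound 3.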